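From One Measured Value to an Untested Side Chain

A few compounds are considered here, and "the series" means these few. Any claim that something is new, unique, unknown or untested is made for them only; others in the source may bear on it.

For the measured compounds named here, four related compounds frame this step, but only one has a number so far. In a functional assay on MOLT-4 cells (Homo sapiens) for inhibition, read by MTT assay, with a stated time of 48 h (a lower number here means a stronger inhibitor, a higher number a weaker inhibitor), compound 1 `CCOC(=O)C(=O)CC(=O)/C=C/c1cn(CCC(C)C)c2ccccc12` shows "not determined" (no result reported), and compound 2 `C/C=C/n1cc(/C=C/C(=O)CC(=O)C(=O)OCC)c2ccccc21` shows "not determined" (no result reported). Compound 3 `CC(C)CCn1cc(/C=C/C(=O)CC(=O)C(=O)O)c2ccccc21` gives 20000 nM, which leaves it with nothing to be ranked against.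

The next candidate is compound 4 `O=C(/C=C/c1cn(CC(=O)N2CCOCC2)c2ccccc12)CC(=O)C(=O)O`, which keeps the shared core and alters one substituent: (morpholin-4-yl)carbonyl in place of isobutyl on a saturated chain carbon bound to an aromatic nitrogen. Put simply, (morpholin-4-yl)carbonyl takes the place of isobutyl on a saturated chain carbon bound to an aromatic nitrogen.

Going by the values given here, no measured pair in this set shows what such a swap does, so any forecast here is loose. The expected change, a 1.5-fold higher number from compound 3 to compound 4 (0.18 log units; within the scatter), is small and leans towards weaker inhibition, and it may not rise beyond the usual scatter. The estimate for compound 4 is 30000 nM, with an expected range from 8000 nM to 100000 nM.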

Compound 4, half-maximal inhibitory concentration: > 40000 nM
Compound 4: only a limit was reported; the forecaster's own chance of this, stated with the estimate: 25%; middle value at least 1.3-fold (0.12 log units) away from the limit.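

In this assay compound 4 gives > 40000 nM as a limit of the assay and not a number. For the compounds shown here, on a saturated chain carbon bound to an aromatic nitrogen, (morpholin-4-yl)carbonyl in place of isobutyl gives an at least 2.0-fold higher number from compound 3 to compound 4 (0.30 log units; that floor lies within the scatter) as the first step that can be read at this position, and the floor of that step lies within the scatter. The swap brings no visible gain in inhibition, while the true size of the step stays hidden behind a single bound: the limit of > 40000 nM in this assay, at which 1 of the 4 values shown sits.

Still open, from the compounds shown here alone, is whether the carbonyl or the morpholine ring matters more for this result. A morpholine ring joined through a plain saturated chain with no carbonyl, or a dimethylamide in place of the ring, would separate the two parts.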